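This account rests on a few compounds, and the source may have more. Where it says the series, first, only, none or still open, it means among the compounds named here.

Measured so far:
compound 1 `Cc1cc(OC(=O)c2ccc(CC(CO[N+](=O)[O-])O[N+](=O)[O-])cc2)n(-c2ccccc2)n1` — 8 h
compound 2 `Cc1cc(OC(=O)OCCCCC(CO[N+](=O)[O-])O[N+](=O)[O-])n(-c2ccccc2)n1` — 3.1 h
compound 3 `Cc1cc(OC(=O)CCCCCO[N+](=O)[O-])n(-c2ccccc2)n1` — 1 h

Of the compounds shown here, three sharing the same core have been tested in a physicochemical assay for metabolic stability, read by HPLC; a lower number here means that the compound disappears faster, a higher number that the compound lasts longer. Compound 1 stands highest of the three: in this assay compound 1 gives 8 h, compound 2 gives 3.1 h, and compound 3 gives 1 h. The gap from compound 1 down to compound 2 is beyond the usual scatter, and the gap down to compound 3 is wider still, so compound 1 is the longest-lasting of the three on the numbers shown.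

Compound 4 `Cc1cc(OC(=O)c2ccc(CCCO[N+](=O)[O-])cc2)n(-c2ccccc2)n1` has not yet been measured. It differs from compound 1 in one place: hydrogen in place of nitrooxy on a saturated chain carbon bound to two saturated chain carbons. In other words, one of the two nitrooxy groups of compound 1 is gone and a single nitrooxy group remains on the chain. Among the measured compounds shown here, no pair of measured compounds shows this exact change, so the size of the step has to be guessed. Compound 3, which also carries a single nitrooxy group on a chain, gives the lowest number, though it differs from compound 1 in more than one place. A modest drop is therefore expected, of roughly a 1.6-fold lower number from compound 1 to compound 4 (0.20 log units; within the scatter), possibly within the scatter. Compound 4 is expected to give about 5 h, somewhere between 2 h and 12 h.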

Compound 4, half-life: 13 h
Compound 4: middle estimate off by 2.6-fold (0.41 log units), on the low side, and the stated range ends below it.
By their numbers in this assay, from the lowest: compound 3; then compound 2; then compounds 1 and 4 (each within the scatter of the next).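

In this assay, among the compounds shown here, the first one-place step in this set shows that hydrogen in place of nitrooxy on a saturated chain carbon bound to two saturated chain carbons gives a 1.6-fold higher number from compound 1 to compound 4 (0.21 log units; within the scatter). For the compounds shown here, the change from 1,2-bis(nitrooxy)ethyl to 2-(nitrooxy)ethyl therefore leaves compound 1 and compound 4 indistinguishable in this read-out, something the earlier compounds could not show, since none of them differed from another in just one place. Nothing measured here bears on why the reading holds at this position.

The compounds shown leave open whether the remaining nitrooxy group on the chain of compound 4 could give way to another group, such as a hydroxyl or an amine, and whether a longer chain would leave the reading just as undisturbed. Compound 2 and compound 3 each differ from compound 4 in more than one place, so the gaps between their numbers cannot be tied to any single group on the shared core.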